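Methoxy for amino on two related cores

This account rests on a few compounds, and the source may have more. Where it says the series, first, only, none or still open, it means among the compounds named here.

Measured so far in a functional assay on MCF7 cells (Homo sapiens) for inhibition, read by MTT assay, with a stated time of 2 days; a higher number here means a weaker inhibitor, a lower number a stronger inhibitor:
compound 1 `Nc1cccc(/C=C/c2cccc(O)c2)c1`: 54 ug/mL
compound 2 `COc1ccc(/C=C/c2ccccc2O)cc1`: 17 ug/mL
compound 3 `Nc1ccc(/C=C/c2ccccc2O)cc1`: 23 ug/mL

Compound 1 gives the highest number of the three; compound 3 and compound 2 both give lower numbers. Going by the values given here, the one step available is a 1.4-fold lower number from compound 3 to compound 2 (0.13 log units; within the scatter), the change being (methoxy in place of amino on an aromatic carbon). Compound 1 and compound 3 have the same atoms joined differently; the difference between the two cores is not broken down here.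

Compound 4 `COc1cccc(/C=C/c2cccc(O)c2)c1` is unmeasured. It differs from compound 1 by methoxy in place of amino on an aromatic carbon, which is the same kind of change as that from compound 3 to compound 2, though not the same: in compound 4 the group sits meta to a group of 9 heavy atoms, in compound 2 para to a group of 9 heavy atoms.

On the core of compound 1 the step is expected to be a 1.4-fold lower number from compound 1 to compound 4 (0.13 log units; within the scatter), resting on compound 3 to compound 2 showing a 1.4-fold lower number from compound 3 to compound 2 (0.13 log units; within the scatter). Compound 4 is thus estimated at 40 ug/mL in this assay, within 20 ug/mL to 80 ug/mL.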

Compound 4, half-maximal inhibitory concentration: 13 ug/mL
Compound 4: middle estimate off by 3.1-fold (0.49 log units), on the high side, outside the stated range (below it).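

In this assay methoxy in place of amino on an aromatic carbon gives a 4.2-fold lower number from compound 1 to compound 4 (0.62 log units; beyond the scatter) and the size of this step does not match the one on the core of compound 2: the same change on two cores in this assay, a 1.4-fold lower number (0.13 log units; within the scatter) from compound 3 to compound 2 and a 4.2-fold lower number (0.62 log units; beyond the scatter) from compound 1 to compound 4, 3.1-fold (0.49 log units) apart, beyond the scatter of two such steps

So in this series the step measured on one core does not give its size on the other, and only the step on the core of compound 1 lies beyond the scatter. With two cores, this does not show whether the gap follows from where the group sits or from some other part of the cores.

Open, going by these compounds, is whether ethoxy or dimethylamino on the same aromatic carbon would track compound 4 or compound 2. Also open, on these data alone, is whether a third core would side with either step.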